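Amide to Urea: Expecting the Number for Compound 4

The source may hold more compounds than are shown below. What is called first, only, known or untested is meant among the compounds shown, and "the series" means these compounds.

Compound 1 `COc1cc(-c2nn(-c3cccc(NC(=O)c4cccc(C(F)(F)F)c4)c3)cc2-c2ccncc2)ccc1Cl` stands highest of the three compounds measured in a functional assay on PC-3 cells (Homo sapiens) for inhibition, read by sulforhodamine B assay, with a stated time of 48 h (on this read-out lower numbers stand for stronger inhibition and higher numbers for weaker inhibition), where compound 1 gives 1230 nM. Compound 2 `COc1cc(-c2nn(-c3cccc(NC(=O)Nc4cccc(C(F)(F)F)c4)c3)cc2-c2ccncc2)ccc1Cl` gives 370 nM, and compound 3 `O=C(Nc1cccc(-n2cc(-c3ccncc3)c(-c3ccc(Cl)c(O)c3)n2)c1)Nc1cc(C(F)(F)F)cc(C(F)(F)F)c1` gives 320 nM. The step of a 3.3-fold lower number from compound 1 to compound 2 (0.52 log units; beyond the scatter) is the one that bears directly on compound 4 `COc1cc(-c2nn(-c3cccc(NC(=O)Nc4ccc(Cl)c(C(F)(F)F)c4)c3)cc2-c2ccncc2)ccc1Cl`, which differs from compound 1 by (4-chloro-3-(trifluoromethyl)phenyl)amino in place of 3-(trifluoromethyl)phenyl on a carbonyl carbon. Compound 4 carries the same amino linkage as compound 2 together with an added chlorine, and the values of compound 2 and compound 3, both carrying that linkage, lie within the usual scatter of each other. A step of similar size and direction is therefore expected, a 4.4-fold lower number from compound 1 to compound 4 (0.64 log units; beyond the scatter). Compound 4 is estimated at 280 nM in this assay, with a range from 100 nM to 800 nM.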

Compound 4, half-maximal inhibitory concentration: 690 nM
Beside the measured number, compound 4's estimate is 2.5-fold (0.39 log units) below it; measured number inside the range.
By their numbers in this assay, from the lowest: compounds 3, 2, 4 and 1 (each within the scatter of the next, the first and the last beyond it).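

In this assay, the step of a 1.8-fold lower number from compound 1 to compound 4 (0.25 log units; within the scatter) and the step of a 1.9-fold higher number from compound 2 to compound 4 (0.27 log units; within the scatter) both lie within the scatter, so compound 4 cannot be placed with either compound 1 or compound 2. With the added chloro, the gain seen for the amino linkage is therefore no longer clear, though the chloro itself produces no step beyond the scatter. Nothing available explains these numbers.

The compounds shown leave open whether a methyl or a bromine in place of this chloro would read differently, and whether a hydroxyl on the shared core, as in compound 3, would alter the outcome.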